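This account rests on a few compounds, and the source may have more. Where it says the series, first, only, none or still open, it means among the compounds named here.

Measured compounds:
compound 1 `Cc1ccc2nc([C@H](CC3CCN(C(=O)C(C)C)CC3)N3C(=O)CN(c4ccc(Oc5ccccc5)cc4)C3=O)n(C)c2c1`: < 0.001 nM
compound 2 `CC(=O)N1CCC(C[C@@H](c2nc3cc(F)ccc3n2C)N2C(=O)CN(c3ccc(Oc4ccccc4)cc3)C2=O)CC1`: 1 nM
compound 3 `CC(C)C(=O)N1CCC(C[C@@H](c2nc3ccccc3n2C)N2C(=O)CN(c3ccc(Oc4ccccc4)cc3)C2=O)CC1`: < 0.001 nM

All three were tested in an assay on cells for antagonist activity at Bile acid receptor (Homo sapiens), read by a luciferase reporter, with a stated time of 24 h; on this read-out lower numbers stand for stronger inhibition and higher numbers for weaker inhibition. For compound 3 the reported value < 0.001 nM is a limit of the assay, not a number. Compound 1 also sits at a limit, < 0.001 nM. Two of the three values shown are such limits (the limit of < 0.001 nM in this assay, at which 2 of the 3 values shown sit), so compound 3 stands at the edge of what this assay can report. The step from compound 1 to compound 3, a step that the two limits leave unreadable from compound 1 to compound 3, cannot be read for that reason. Within the data shown here, compound 2 gives 1 nM in this assay; it differs from compound 3 in two places at once, so no single step links the two.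

Compound 4 `CC(C)C(=O)N1CCC(C[C@@H](c2nc3cc(F)ccc3n2C)N2C(=O)CN(c3ccc(Oc4ccccc4)cc3)C2=O)CC1` differs from compound 3 by fluoro in place of hydrogen on an aromatic carbon. Among the measured compounds shown here, no measured step isolates this change: compound 2 carries the same fluoro but also a second alteration. With compound 3 at a limit, the size of the step in this assay is open, and a further limit is quite possible. Compound 4 is estimated at 0.005 nM (from 0.0005 nM to 0.5 nM), which means an expected step of an at least 5.0-fold higher number from compound 3 to compound 4 (0.69 log units; beyond the scatter).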

Compound 4, half-maximal inhibitory concentration: 0.06 nM
Compound 4: middle estimate off by 12-fold (1.08 log units), on the low side; low and high end bracket the measured number.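

In this assay, fluoro in place of hydrogen on the six-membered aromatic ring gives an at least 60-fold higher number from compound 3 to compound 4 (1.77 log units; beyond the scatter), and replacing 1,6-dimethyl-1H-benzimidazol-2-yl with 5-fluoro-1-methyl-1H-benzimidazol-2-yl gives an at least 60-fold higher number from compound 1 to compound 4 (1.77 log units; beyond the scatter), so both changes weaken inhibition. Among these compounds, with the fluoro in place, isopropyl in place of methyl on the carbonyl carbon gives a 17-fold lower number from compound 2 to compound 4 (1.22 log units; beyond the scatter), the first single change in this set that shows the isopropyl group strengthening inhibition. The full size of the first two steps cannot be read because each starts from a limit: the limit of < 0.001 nM in this assay, at which 2 of the 4 values shown sit.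

On these data alone, it remains open whether a chloro, methoxy or amino group on the same aromatic carbon would behave as fluoro does. Also open, as far as these compounds go, is whether isopropyl in place of methyl has a step of similar size without the fluoro.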